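This account rests on a few compounds, and the source may have more. Where it says the series, first, only, none or still open, it means among the compounds named here.

Compound 1 `C=C(C)C(=O)NC(=O)NC1=CS(=O)(=O)O[C@@]12[C@@H](CO[Si](C)(C)C(C)(C)C)O[C@@H](n1cc(C)c(=O)n(C)c1=O)[C@@H]2O[Si](C)(C)C(C)(C)C`, compound 2 `Cc1cn([C@@H]2O[C@H](CO[Si](C)(C)C(C)(C)C)[C@@]3(OS(=O)(=O)C=C3NCC(=O)C(=O)O)[C@H]2O[Si](C)(C)C(C)(C)C)c(=O)n(C)c1=O` and compound 3 `COC(=O)C(=O)CNC1=CS(=O)(=O)O[C@@]12[C@@H](CO[Si](C)(C)C(C)(C)C)O[C@@H](n1cc(C)c(=O)n(C)c1=O)[C@@H]2O[Si](C)(C)C(C)(C)C` share one core and differ only in the group on an amine nitrogen. In a functional assay on HEL cells (Homo sapiens) (on this read-out higher numbers stand for lower toxicity in this test and lower numbers for higher toxicity in this test), compound 1 gives 1200 nM, the lowest of the two numbers shown, while compound 2 gives 146000 nM. Compound 3 gives only a limit of this test, > 200000 nM. The measured steps, a 120-fold higher number from compound 1 to compound 2 (2.09 log units; beyond the scatter) and an at least 160-fold higher number from compound 1 to compound 3 (2.22 log units; beyond the scatter), both remove the ((1-methylethenyl)carbonyl)carbamoyl group and both are large. Compound 4 `Cc1cn([C@@H]2O[C@H](CO[Si](C)(C)C(C)(C)C)[C@@]3(OS(=O)(=O)C=C3NCCC(N)=O)[C@H]2O[Si](C)(C)C(C)(C)C)c(=O)n(C)c1=O` is not yet measured; it differs from compound 1 by 2-carbamoylethyl in place of ((1-methylethenyl)carbonyl)carbamoyl on an amine nitrogen. Since this change also removes that group, a similarly large rise in this assay is expected, with a fair chance of reaching (the limit of > 200000 nM in this assay, at which 1 of the 3 values shown sits). Compound 4 is therefore estimated at 150000 nM, between 30000 nM and 250000 nM, a step of a 130-fold higher number from compound 1 to compound 4 (2.10 log units; beyond the scatter).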

Compound 4, half-maximal cytotoxic concentration: 14800 nM
Estimate against measurement, compound 4: 10-fold (1.01 log units) above, outside the stated range (below it).
By their numbers in this assay, from the lowest: compound 1; then compound 4; then compound 2. At a limit, above all of these: compound 3.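

Removing the ((1-methylethenyl)carbonyl)carbamoyl group does not alone settle the outcome at this amine nitrogen: with 2-carbamoylethyl in its place there is a 12-fold higher number from compound 1 to compound 4 (1.09 log units; beyond the scatter). The replacing group also matters, since there is a 9.9-fold lower number from compound 2 to compound 4 (0.99 log units; beyond the scatter) and an at least 13-fold lower number from compound 3 to compound 4 (1.13 log units; beyond the scatter). Only compound 3 sits at a limit of this test: the limit of > 200000 nM in this assay, at which 1 of the 4 values shown sits.

Still open, from the compounds shown here alone, is how a longer chain bearing the same carbamoyl group, or a chain ending in an amine, would read in this assay. These compounds also cannot show which part of 2-carbamoylethyl matters.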